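A few compounds are considered here, and "the series" means these few. Any claim that something is new, unique, unknown or untested is made for them only; others in the source may bear on it.

Measured compounds:
- Compound 1, `CCCCN(c1nc2ccccc2o1)[C@H](C)c1ccc(-c2ccccc2-c2nnn[nH]2)cc1`: 0.000713
- Compound 2, `CCCCN(c1nc2c(C(=O)O)cccc2o1)[C@H](C)c1ccc(-c2ccccc2-c2nnn[nH]2)cc1`: 0.000285
- Compound 3, `CCCCN(c1nc2c(C(=O)NS(C)(=O)=O)cccc2o1)[C@H](C)c1ccc(-c2ccccc2-c2nnn[nH]2)cc1`: 0.00103

In an ADME assay on the whole organism (plasma, Macaca fascicularis) for protein binding, read by LC-MS, using equilibrium dialysis and cassette dosing, with a stated time of 24 h, at a dose of 1 mg/kg by the oral route (on this read-out lower numbers stand for a smaller free fraction and higher numbers for a larger free fraction), compound 3 stands highest of the three numbers, though the step of a 1.4-fold higher number from compound 1 to compound 3 (0.16 log units; within the scatter) is within the scatter, while the step of a 3.6-fold higher number from compound 2 to compound 3 (0.56 log units; beyond the scatter) is beyond it. The step to the unmeasured compound 4, `CCCCN(c1nc2c(NC(C)=O)cccc2o1)[C@H](C)c1ccc(-c2ccccc2-c2nnn[nH]2)cc1`, is acetamido in place of (methylsulfonyl)carbamoyl on an aromatic carbon. Among the compounds with values here, no measured step puts an acetamido group in; the step of a 2.5-fold lower number from compound 1 to compound 2 (0.40 log units; beyond the scatter) and the step of a 3.6-fold higher number from compound 2 to compound 3 (0.56 log units; beyond the scatter) bracket what the group at this position has done so far, with the carboxy compound the only one clearly apart. Since compound 4 carries neither of the groups that set compound 2 and compound 3 apart, the expectation is that the step of a 1.1-fold lower number from compound 3 to compound 4 (0.06 log units; within the scatter) is small and within the scatter, with a value for compound 4 near that of compound 1. Compound 4 is therefore estimated at 0.0009, with a range from 0.0004 to 0.002.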

Compound 4, unbound fraction: 0.00102
Estimate against measurement, compound 4: 1.1-fold (0.05 log units) below; the measured number falls inside the stated range.
By their numbers in this assay, from the lowest: compound 2; then compounds 1, 4 and 3 (each within the scatter of the next).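

At this aromatic carbon, the acetamido group cannot be told apart from the (methylsulfonyl)carbamoyl group in this assay (a 1.0-fold lower number from compound 3 to compound 4 (0.00 log units; within the scatter)). Acetamido in place of carboxy gives a separation beyond the scatter (a 3.6-fold higher number from compound 2 to compound 4 (0.55 log units; beyond the scatter)), much as the (methylsulfonyl)carbamoyl group did (a 3.6-fold higher number from compound 2 to compound 3 (0.56 log units; beyond the scatter)). Acetamido in place of hydrogen stays within the scatter (a 1.4-fold higher number from compound 1 to compound 4 (0.16 log units; within the scatter)), so among these four compounds only the carboxy compound, compound 2, lies clearly apart from compound 1, while compound 3 and compound 4 do not.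

From the compounds shown here alone, whether a primary amine or a methyl ester at this aromatic carbon would fall with compound 2 or with the other three compounds remains open. Nothing shown here explains why compound 2 stands apart.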